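A few compounds are considered here, and "the series" means these few. Any claim that something is new, unique, unknown or untested is made for them only; others in the source may bear on it.

Measured compounds:
- Compound 1 `COc1cc(C)cc(-c2c(-c3ccnc(-c4ccc(C(C)=O)cc4)c3)cnn2CC#N)c1` gives 92% in a functional assay on T47D cells (Homo sapiens) for cytotoxicity, read by sulforhodamine B assay, with a stated time of 48 h, tested at 0.01 uM; a lower number here means a stronger effect, a higher number a weaker effect of the compound at the concentration tested.
- Compound 2 `Cc1cc(O)cc(-c2nn(CC#N)cc2-c2ccnc(-c3ccc(Oc4ccccc4)cc3)c2)c1` gives 86% in this assay.
- Compound 3 `Cc1cc(O)cc(-c2nn(CC#N)cc2-c2ccnc(-c3ccc(N(C)C)cc3)c2)c1` gives 90% in this assay.

All three compounds share one core, and the read-out in this assay is a percentage at a single concentration. Compound 1 has the highest of the three numbers, but the nearest value, that of compound 3, and the furthest, that of compound 2, both sit within the scatter of repeated measurements, so the three compounds cannot be told apart on these numbers.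

Compound 4 `COc1cc(C)cc(-c2c(-c3ccnc(-c4ccc(N(C)C)cc4)c3)cnn2CC#N)c1` differs from compound 1 in one place: dimethylamino in place of acetyl on an aromatic carbon. Among the measured compounds shown here, the only measured step that touches this position is the one between compound 2 and compound 3, where a dimethylamino group also enters on the same aromatic carbon, there in place of phenoxy: a number 4 percentage points higher from compound 2 to compound 3 (within the scatter). That change left the read-out essentially unmoved, and the three measured compounds already lie close together whatever group sits at this position.

The change from compound 1 to compound 4 is therefore expected to produce no step beyond the scatter in this assay, that is a number 1 percentage points lower from compound 1 to compound 4 (within the scatter). For compound 4 the estimated value is 91%, with an expected range from 82% to 100%.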

Compound 4, a percentage reported as activity, at one concentration (the size of the read-out at that concentration, not a potency): 36%
Estimate against measurement, compound 4: 55 percentage points above, and the stated range ends above it.
By their numbers in this assay, from the lowest: compound 4; then compounds 2, 3 and 1 (each within the scatter of the next).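

In this assay, among the compounds shown here, the change from 4-acetylphenyl to 4-(dimethylamino)phenyl gives a number 56 percentage points lower from compound 1 to compound 4 (beyond the scatter), so this position, on an aromatic carbon para to a large group, can move the read-out far more than the close values of the earlier compounds suggested. The same dimethylamino group also entered in a number 4 percentage points higher from compound 2 to compound 3 (within the scatter), so its presence at this position does not by itself bring a large step, and the outcome also depends on the group it replaces, the rest of the molecule, or both. Acetyl and dimethylamino match in heavy-atom count and in hydrogen-bond donors and acceptors, so those counts do not separate them, and no measurement shown here explains the large step.

Compound 3 also carries dimethylamino but differs from compound 4 in more than one place, so the compounds shown do not reveal which other feature matters. As far as these compounds go, it also remains open how a primary amine, a diethylamino group or a morpholine ring at this position would behave, and a reading at a single concentration gives no potency for any of them.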